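Chain branching in the carbamate series: compound 4

A few compounds are considered here, and "the series" means these few. Any claim that something is new, unique, unknown or untested is made for them only; others in the source may bear on it.

Compound 3 `CCCC(COC(N)=O)C(C)C` stands at the upper end of the three numbers measured in a functional assay on the whole organism (strain Sprague-Dawley albino) with Rattus norvegicus as the target, with a stated time of 0.5 h (on this read-out higher numbers stand for an effect only at larger amounts of compound and lower numbers for an effect already at smaller amounts), though its gap to compound 2 `CCCC(C(N)=O)C(C)CC` with 84 mg/kg and to compound 1 `CCC(COC(N)=O)C(C)C` with 81 mg/kg lies within the scatter; compound 3 gives 107 mg/kg. Compound 4 `CCC(C)C(COC(N)=O)C(C)C` differs from compound 3 by methyl in place of hydrogen on a saturated chain carbon bound to two saturated chain carbons. For the measured compounds named here, the one earlier step of the same kind, a 1.3-fold higher number from compound 1 to compound 3 (0.12 log units; within the scatter), stayed within the scatter, and no other measured pair bears on this change. A step of a 1.1-fold higher number from compound 3 to compound 4 (0.05 log units; within the scatter) is therefore expected in this assay, with no direction beyond the scatter. Compound 4 is estimated at 120 mg/kg, in the range 60 mg/kg to 240 mg/kg.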

Compound 4, dose for half-maximal effect: 114 mg/kg
Compound 4: middle estimate off by 1.1-fold (0.02 log units), on the high side, and the stated range covers the measured number.
By their numbers in this assay, from the lowest: compounds 1, 2, 3 and 4 (each within the scatter of the next).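

In this assay the change from propyl to sec-butyl gives a 1.1-fold higher number from compound 3 to compound 4 (0.03 log units; within the scatter) and thus no shift beyond the scatter. Ethyl in place of hydrogen on the same saturated chain carbon gives a 1.4-fold higher number from compound 1 to compound 4 (0.15 log units; within the scatter) and also stays within the scatter, so this position tolerates both methyl and ethyl in place of hydrogen in compound 3 and compound 1 without a readable change. No measurement at hand accounts for these numbers. On these data alone, whether a longer chain, a hydroxyl group or a phenyl ring on this carbon would move the number beyond the scatter remains open.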